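A bromo in place of the 3-hydroxyphenyl arm in cytotoxicity

A few compounds are considered here, and "the series" means these few. Any claim that something is new, unique, unknown or untested is made for them only; others in the source may bear on it.

Compound 3 `CCOC(=O)CCCCCOc1cccc(CN(C(=O)c2ccc(-c3cccc(O)c3)cc2)C(C)C)c1` is one of three close relatives tested in an ADME assay on Raji cells (Homo sapiens) for cytotoxicity, read by CellTiter-Glo and resazurin assay, with a stated time of 72 h; on this read-out higher numbers stand for an effect only at larger amounts of compound and lower numbers for an effect already at smaller amounts. In this assay compound 3 reaches only the limit of > 26000 nM, so no number is known for it. Compound 1 `CCOC(=O)CCCCCOc1cccc(CN(C(=O)c2ccc(-c3cccc(N(C)C)c3)cc2)C(C)C)c1` likewise stops at the limit > 26000 nM in this assay. Compound 2 `CCOC(=O)CCCCCOc1cccc(CN(C(=O)c2ccc(-c3ccc4c(c3)OCCO4)cc2)C(C)C)c1` ends at the limit > 24400 nM in this assay. All three values are thus limits rather than numbers, as the limit of > 26000 nM in this assay, at which 2 of the 3 values shown sit, and the limit of > 24400 nM in this assay, at which 1 of the 3 values shown sits, show. The measured steps among them are all unreadable: a step that the two limits leave unreadable from compound 1 to compound 2, a step that the two limits leave unreadable from compound 1 to compound 3 and a step that the two limits leave unreadable from compound 2 to compound 3. Compound 4 `CCOC(=O)CCCCCOc1cccc(CN(C(=O)c2ccc(Br)cc2)C(C)C)c1` differs from compound 3 in one place: bromo in place of 3-hydroxyphenyl on an aromatic carbon. For the measured compounds named here, none of the measured steps can be read, so they give no size or direction; what they do show is that three different groups on the aromatic carbon all leave the compounds without a measurable effect in this assay. Compound 4 is therefore expected to remain at the limit as well, with the step of a number no higher from compound 3 to compound 4 (the limit leaves the size open) expected to be small or nil. In this assay compound 4 is estimated at 26000 nM, ranging from 10000 nM to 60000 nM.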

Compound 4, half-maximal effective concentration: > 26000 nM
Compound 4: a limit, no number; the forecaster's own chance of this, stated with the estimate: 80%; the middle value sits exactly at the limit.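

Compound 4 also ends at a limit rather than a number in this assay, so its steps to compound 1, compound 2 and compound 3 cannot be read. The compounds shown leave open at what concentration any of them would show an effect in this assay, and whether exchanging the group on the aromatic carbon changes that concentration.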